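This account rests on a few compounds, and the source may have more. Where it says the series, first, only, none or still open, it means among the compounds named here.

Measured so far in a functional assay on CHO cells for antagonist activity at metabotropic glutamate receptor 5 (Rattus norvegicus), read by calcium flux; a lower number here means a stronger inhibitor, a higher number a weaker inhibitor:
compound 1 `Cc1cccc(-c2cc3ncccc3cn2)c1` — 1270 nM
compound 2 `Cc1ccc2ccc(-c3cc(F)cc(F)c3)nc2n1` — 181 nM
compound 3 `Cc1ccc2cnc(-c3ccccc3)cc2n1` — > 30000 nM

Compound 3 stands apart: in this assay its value is only a limit, (the limit of > 30000 nM in this assay, at which 1 of the 3 values shown sits), not a number. Compound 1 and compound 2 each give a measured value in this assay. Compound 4 `Cc1cccc(-c2cc3nc(C)ccc3cn2)c1` is not yet measured. It differs from compound 3 by methyl in place of hydrogen on an aromatic carbon, on an aromatic carbon of a six-membered aromatic ring of carbon only, meta to a large group. For the measured compounds named here, with no measured step of this kind among the compounds, the direction cannot be read from the data. Because compound 1 gives 1270 nM in this assay, compound 4 is expected to move toward a measurable value, a step of an at least 10-fold lower number from compound 3 to compound 4 (1.00 log units; beyond the scatter). The estimate for compound 4 is 3000 nM, between 800 nM and 15000 nM.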

Compound 4, half-maximal inhibitory concentration: 676 nM
Beside the measured number, compound 4's estimate is 4.4-fold (0.65 log units) above it; measured number below the stated range.
By their numbers in this assay, from the lowest: compound 2; then compounds 4 and 1 (each within the scatter of the next). At a limit, above all of these: compound 3.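

For the compounds shown here, on the aromatic carbon of the six-membered aromatic ring of carbon only, meta to a large group, methyl in place of hydrogen gives the first measured step at this position in this assay, namely an at least 44-fold lower number from compound 3 to compound 4 (1.64 log units; beyond the scatter). The same kind of change at another place on the core gives a 1.9-fold lower number from compound 1 to compound 4 (0.27 log units; within the scatter), so the two places do not respond alike. Compound 3 gives only a limit, so the larger step is a bound, not a measured size: the limit of > 30000 nM in this assay, at which 1 of the 4 values shown sits. Open, as far as these compounds go, is whether an ethyl group, a methoxy group or an amine at the same carbon would match methyl.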